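Methoxy for Trifluoromethyl on a Core That Gives Only Limits

This account rests on a few compounds, and the source may have more. Where it says the series, first, only, none or still open, it means among the compounds named here.

Compound 1 `O=S(=O)(Nc1ccc2oc(-c3ccccc3)nc2c1)c1cccc(C(F)(F)F)c1`: in an assay on isolated protein for inhibition of malate dehydrogenase, mitochondrial (Sus scrofa), with stated times of 45 min and 30 min (a lower number here means a stronger inhibitor, a higher number a weaker inhibitor), compound 1 gives only a limit, > 63000 nM.
Compound 2 `O=S(=O)(Nc1ccc(-c2nc3ccccc3o2)cc1)c1cccc(O)c1`: in this assay compound 2 gives only a limit, > 63000 nM.
Compound 3 `O=S(=O)(Nc1ccc2oc(-c3ccccc3)nc2c1)c1ccc(F)c(C(F)(F)F)c1`: in this assay compound 3 gives only a limit, > 63000 nM.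

Compound 1 stands at the limit of this assay; no number is known for it, and the two other values shown are limits as well. The step from compound 1 to compound 3 is a step that the two limits leave unreadable from compound 1 to compound 3, so the effect of fluoro in place of hydrogen on an aromatic carbon cannot be read. All three compounds sit at the limit of > 63000 nM in this assay, at which 3 of the 3 values shown sit.

Compound 4 `COc1cccc(S(=O)(=O)Nc2ccc3oc(-c4ccccc4)nc3c2)c1` differs from compound 1 in one place: methoxy in place of trifluoromethyl on an aromatic carbon, a methoxy in place of trifluoromethyl on an aromatic carbon of a six-membered aromatic ring of carbon only, meta to a large group. Going by the values given here, no measured step bears on this exchange, and the only step on the shared core is unreadable. The step expected here is a step that the limit leaves unreadable from compound 1 to compound 4, resting on no measured change. Compound 4 is expected most likely to return a limit once more in this assay. For compound 4 the estimate is 100000 nM, with a range from 30000 nM to 300000 nM.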

Compound 4, half-maximal inhibitory concentration: > 63000 nM
Compound 4 ended at the assay's limit; the forecaster's own chance of this, stated with the estimate: 85%; the middle value lies beyond the limit too.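

Compound 1 and compound 4 both give only a limit in this assay, so no step can be read between them: the limit of > 63000 nM in this assay, at which 4 of the 4 values shown sit.

The compounds shown leave open how strongly any of them inhibits the enzyme, and whether any exchange on the shared core changes that.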